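The compounds below may be only part of what the source reports. "The series", "measured", "known", "first", "only" and "open" are said of these compounds alone.

Compound 1, `O=C(CSc1snnc1-c1ccc(Br)cc1Br)Nc1ccccc1F`, in an ADME assay on MT4 cells (Homo sapiens) for cytotoxicity, read by MTT assay, with a stated time of 5 days (on this read-out lower numbers stand for higher toxicity in this test and higher numbers for lower toxicity in this test), gives >= 27800 nM, and this is a limit of the assay rather than a number. Compound 2, `O=C(CSc1snnc1-c1ccc(Br)cc1Br)Nc1cccnc1Cl`, in this assay gives > 240000 nM, again a limit. Compound 3, `O=C(CSc1snnc1-c1ccc(Br)cc1Br)Nc1nccs1`, in this assay gives 87800 nM.

Compound 1 therefore stands only as a limit in this assay, and one of the two other values shown is a limit as well, so its place among the three cannot be fixed.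

Compound 4, `Cc1ccccc1NC(=O)CSc1snnc1-c1ccc(Br)cc1Br`, differs from compound 1 in one respect: methyl in place of fluoro on an aromatic carbon. For the measured compounds named here, none of the measured steps touches this particular exchange; each of them swaps the whole ring on the amide-type nitrogen. The step that the two limits leave unreadable from compound 1 to compound 2 is unreadable, as is a step that the limit leaves unreadable from compound 1 to compound 3, while an at least 2.7-fold lower number from compound 2 to compound 3 (0.43 log units; beyond the scatter) is at least modest. Taken together they give no guide to a small exchange on the ring that compound 1 carries, and the expected change in this assay is none beyond the scatter, with compound 4 expected to sit close to where compound 1 sits.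

Compound 4 is therefore estimated at 40000 nM, within a range of 15000 nM to 150000 nM, which means an expected step that the limit leaves unreadable from compound 1 to compound 4.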

Compound 4, half-maximal cytotoxic concentration: 202000 nM
Compound 4: the middle estimate sits 5.1-fold (0.70 log units) below what was measured; the whole stated range lies below it.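

In this assay, compound 4 gives a measured number for a 2-methylphenyl group on the amide-type nitrogen, and the change is a 2.3-fold higher number from compound 3 to compound 4 (0.36 log units; beyond the scatter), so here the ring of carbon only reads as less toxic in this test than 1,3-thiazol-2-yl. The comparison with the 2-chloropyridin-3-yl group in compound 2 rests on a limit and shows an at least 1.1-fold lower number from compound 2 to compound 4 (0.07 log units; that floor lies within the scatter), a floor that does not separate the two compounds. The exchange of fluoro for methyl itself, the step from compound 1 to compound 4, cannot be read, because the value for compound 1 is a limit and not a number: the limit of >= 27800 nM in this assay, at which 1 of the 4 values shown sits.

The compounds shown therefore leave open how much, if at all, replacing fluoro with methyl on this ring changes the result. They also leave open how a methoxy group, an amine or a carboxylic acid at this same place on the ring would read in this assay.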